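One Substituent Swap on a Shared Core

The source may hold more compounds than are shown below. What is called first, only, known or untested is meant among the compounds shown, and "the series" means these compounds.

Of the compounds shown here, two built on a shared core have been measured. Compound 1 `Fc1cccc(Nc2nc3nonc3nc2Nc2ccccc2F)c1` in an assay on mitochondria from L6 cells (Rattus norvegicus) for activation, with a stated time of 90 min (a higher number here means that more compound is needed for the effect, a lower number that less compound is needed), gives 190 nM. Compound 2 `Oc1nc2nonc2nc1Nc1ccc(SC(F)(F)F)cc1` in this assay gives 1400 nM. Going by the values given here, of the two numbers, compound 2 stands at the higher one; its only neighbour, compound 1, sits at a lower value, and that gap is beyond the usual scatter. Among the compounds with values here, the two measured compounds differ in more than one place, so no single-change step is available to guide an expectation.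

Compound 3 `Oc1nc2nonc2nc1Nc1ccc(OC(F)F)cc1` has not yet been measured. Compared with compound 2, the change is difluoromethoxy in place of (trifluoromethyl)sulfanyl on an aromatic carbon. Both groups are small, and neither adds a ring. The measured compounds give no example of this particular swap, so there is no reason from the data to expect a large move in either direction; the step from compound 2 to compound 3 is expected to be a 1.1-fold higher number from compound 2 to compound 3 (0.03 log units; within the scatter), probably within the scatter. Compound 3 is therefore estimated at 1500 nM in this assay, with a range from 500 nM to 4000 nM.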

Compound 3, half-maximal effective concentration: 20600 nM
Compound 3: the middle estimate sits 14-fold (1.14 log units) below what was measured; measured number outside the range, above it.
By their numbers in this assay, from the lowest: compound 1; then compound 2; then compound 3.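

In this assay, the group on the aromatic carbon para to a large group turns out to matter a great deal: difluoromethoxy in place of (trifluoromethyl)sulfanyl gives a 15-fold higher number from compound 2 to compound 3 (1.17 log units; beyond the scatter) and so a step far beyond what repeated measurements would produce. Going by these compounds alone, this is the first single-change comparison available on the shared core, and it shows that this position is sensitive even to a modest swap. The two groups are close in heavy-atom count, match in hydrogen-bond donors and acceptors, and neither brings a ring or a net charge, so these counts alone do not foretell the outcome here. No measurement is available that would explain the size of this step.

A single step cannot separate the part played by the sulfur from that of the oxygen, or the part played by the third fluorine from the rest of the group. Going by these compounds, whether trifluoromethoxy, with its oxygen and three fluorines, or methylsulfanyl, with its sulfur and no fluorine, stays nearer to compound 2 or to compound 3 remains open.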